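The compounds below may be only part of what the source reports. "The series", "measured", "known", "first", "only" and "open" are said of these compounds alone.

In a functional assay on HCT-116 cells (Homo sapiens) for inhibition, read by sulforhodamine B assay, with a stated time of 48 h, tested at 50 uM (on this read-out lower numbers stand for less inhibition of growth and higher numbers for more inhibition of growth at the one concentration tested), compound 1 `COc1cc(/C=C/C(=O)/C=C/c2cccc3ccccc23)ccc1OCc1cn(CCCCOc2cc(=O)oc3ccccc23)nn1` gives 56% and compound 2 `COc1ccccc1/C=C/C(=O)/C=C/c1ccc(OCc2cn(CCCCOc3cc(=O)oc4ccccc34)nn2)c(OC)c1` gives 43% while compound 3 `COc1cc(/C=C/C(=O)/C=C/c2cccs2)ccc1OCc1cn(CCCCOc2cc(=O)oc3ccccc23)nn1` gives 41% at the single concentration tested. Compound 3 is level with compound 2 (the measured step is a number 2 percentage points lower from compound 2 to compound 3 (within the scatter)) and clearly under compound 1 (the measured step is a number 15 percentage points lower from compound 1 to compound 3 (beyond the scatter)).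

The next change leads to compound 4 `COc1ccc(/C=C/C(=O)/C=C/c2ccc(OCc3cn(CCCCOc4cc(=O)oc5ccccc45)nn3)c(OC)c2)cc1` and puts 4-methoxyphenyl in place of thiophen-2-yl on a double-bonded chain carbon bound to a double-bonded chain carbon (the difference is 4-methoxyphenyl in place of thiophen-2-yl on a double-bonded chain carbon bound to a double-bonded chain carbon). For the measured compounds named here, no measured compound carries 4-methoxyphenyl. The closest evidence is the swap between 2-methoxyphenyl and thiophen-2-yl (the step is a number 2 percentage points lower from compound 2 to compound 3 (within the scatter)), which stays within the scatter. Going by the values given here, only the loss of naphthalen-1-yl has moved the number so far, by a modest amount in both cases (the steps are a number 13 percentage points lower from compound 1 to compound 2 (beyond the scatter) and a number 15 percentage points lower from compound 1 to compound 3 (beyond the scatter)). In this assay the step expected is a number 3 percentage points higher from compound 3 to compound 4 (within the scatter) (an estimate, slightly upward and not beyond the scatter). Compound 4 is estimated at 44% (expected range 32% to 56%).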

Compound 4, percent growth inhibition at one concentration: 40%
Compound 4: middle estimate off by 4 percentage points, on the high side; the measured number falls inside the stated range.
By their numbers in this assay, from the lowest: compounds 4, 3 and 2 (each within the scatter of the next); then compound 1.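

In this assay, 4-methoxyphenyl on a double-bonded chain carbon bound to a double-bonded chain carbon is level with thiophen-2-yl (a number 1 percentage points lower from compound 3 to compound 4 (within the scatter)) and with 2-methoxyphenyl (a number 3 percentage points lower from compound 2 to compound 4 (within the scatter)), so a third group, and the first with a 4-methoxy substituent, also leaves the number unmoved. Naphthalen-1-yl stays apart from all three, now also against 4-methoxyphenyl (a number 16 percentage points lower from compound 1 to compound 4 (beyond the scatter)), and every step beyond the scatter at this position still involves its loss. No available measurement accounts for this grouping.

Going by these compounds, it remains open whether naphthalen-2-yl would keep the higher number of compound 1, and whether a phenyl carrying a dimethylamino group or a carboxylic acid would depart from the level of compound 2, compound 3 and compound 4. On these data alone, with one tested concentration, the comparison across a range of concentrations also remains open.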